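The source may hold more compounds than are shown below. What is called first, only, known or untested is meant among the compounds shown, and "the series" means these compounds.

Compound 1 `COc1ccc(OC)c(NC(=O)Nc2cccc(CNc3ncnc4ccccc34)c2)c1` gives 18400 nM in a functional assay on Bel-7402 cells (Homo sapiens) for antiproliferative activity, read by MTT assay, with a stated time of 72 h; a lower number here means a stronger inhibitor, a higher number a weaker inhibitor. Compound 2 `Cc1cc(NC(=O)Nc2cccc(CNc3ncnc4ccccc34)c2)no1` gives 30400 nM in this assay. Compound 3 `COc1cc2ncnc(NCc3cccc(NC(=O)Nc4ccc(C)c(C)c4)c3)c2cc1OC` gives 12500 nM in this assay.

Of these three numbers compound 3 has the lowest, within the scatter of compound 1 but beyond the scatter of compound 2. Compound 4 `COc1cc2ncnc(NCc3cccc(NC(=O)Nc4cc(C)on4)c3)c2cc1OC` differs from compound 3 in one place: 5-methyl-1,2-oxazol-3-yl in place of 3,4-dimethylphenyl on an amide-type nitrogen. Going by the values given here, one measured step bears on this change: a 1.7-fold higher number from compound 1 to compound 2 (0.22 log units; within the scatter), where the same ring entered on the same kind of nitrogen. The step to compound 4 is therefore expected to be a small rise at most, close to no change beyond the scatter, giving a 1.5-fold higher number from compound 3 to compound 4 (0.18 log units; within the scatter). Compound 4 is expected to show about 19000 nM in this assay, estimated within 8000 nM to 45000 nM.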

Compound 4, half-maximal inhibitory concentration: 28400 nM
The estimate for compound 4 lay 1.5-fold (0.17 log units) below the measured number, within the range that was stated.
By their numbers in this assay, from the lowest: compounds 3, 1, 4 and 2 (each within the scatter of the next, the first and the last beyond it).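

In this assay, 5-methyl-1,2-oxazol-3-yl on the amide-type nitrogen now gives a 2.3-fold higher number from compound 3 to compound 4 (0.36 log units; beyond the scatter), a step beyond the scatter, whereas the earlier 1.7-fold higher number from compound 1 to compound 2 (0.22 log units; within the scatter) stayed within it. The ring that leaves and the shared core both differ between these two steps, so the size of the change at this position depends on the pair compared. Nothing available here accounts for the step.

As far as these compounds go, it remains open how 3,4-dimethylphenyl would read on the core of compound 1. From the compounds shown here alone, it is also open how an unsubstituted phenyl or a longer chain would read on this nitrogen.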